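The compounds below may be only part of what the source reports. "The series", "measured", "known", "first", "only" and "open" are said of these compounds alone.

Working notes on the series. Among the measured compounds shown here, compound 3 `O=C(c1ccc(C(F)(F)F)cc1)N(/N=N/c1ccc([N+](=O)[O-])cc1C(F)(F)F)c1ccc([N+](=O)[O-])cc1C(F)(F)F` gives 690 nM in a functional assay on HeLa cells (Homo sapiens) for cytotoxicity, read by MTT assay, with a stated time of 72 h (a higher number here means a weaker inhibitor, a lower number a stronger inhibitor), standing second highest of the three numbers so far; its nearest neighbour is compound 2 `O=C(c1cccc(C(F)(F)F)c1)N(/N=N/c1ccc([N+](=O)[O-])cc1C(F)(F)F)c1ccc([N+](=O)[O-])cc1C(F)(F)F` with 750 nM, and compound 1 `O=C(c1ccccc1)N(/N=N/c1ccc([N+](=O)[O-])cc1C(F)(F)F)c1ccc([N+](=O)[O-])cc1C(F)(F)F` with 600 nM is furthest, yet both steps to it, a 1.2-fold higher number from compound 1 to compound 3 (0.06 log units; within the scatter) and a 1.1-fold lower number from compound 2 to compound 3 (0.04 log units; within the scatter), are within the scatter, as is a 1.3-fold higher number from compound 1 to compound 2 (0.10 log units; within the scatter).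

Compound 4 `O=C(CCl)N(/N=N/c1ccc([N+](=O)[O-])cc1C(F)(F)F)c1ccc([N+](=O)[O-])cc1C(F)(F)F` differs from compound 3 by chloromethyl in place of 4-(trifluoromethyl)phenyl on a carbonyl carbon. The measured steps only move a trifluoromethyl around the aryl of the acyl group; none removes that ring, so they bear on this change only loosely. Since those steps were all within the scatter, the working expectation for compound 4 is a step of a 1.0-fold higher number from compound 3 to compound 4 (0.01 log units; within the scatter), with no clear direction, and a value near 700 nM, estimated to fall between 250 nM and 2000 nM.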

Compound 4, half-maximal inhibitory concentration: 800 nM
The estimate for compound 4 lay 1.1-fold (0.06 log units) below the measured number; low and high end bracket the measured number.
By their numbers in this assay, from the lowest: compounds 1, 3, 2 and 4 (each within the scatter of the next).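

On the carbonyl carbon, chloromethyl in place of an aryl group removes the ring altogether, yet in this assay the steps are a 1.2-fold higher number from compound 3 to compound 4 (0.06 log units; within the scatter) and a 1.1-fold higher number from compound 2 to compound 4 (0.03 log units; within the scatter) as well as a 1.3-fold higher number from compound 1 to compound 4 (0.12 log units; within the scatter) at this position. The earlier compounds shown here only moved or added a trifluoromethyl on that ring, whereas these four compounds show that the number holds without the ring.

As far as these compounds go, whether a plain methyl, an amine, a carboxylic acid or a longer chain on this carbonyl carbon would behave alike stays open. Nothing available explains this flat picture.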